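An Azido Group Added to the Benzyl Ring of Compound 2

The source may report more compounds than this note shows. Statements on the series, on what has been measured and on what is new or still open speak of the compounds shown alone.

Compound 1 `COc1ccc(CN(C(=O)CSC(=S)N2CCN(C(C)=O)CC2)c2cc(OC)c(OC)c(OC)c2)cc1`: 1370 nM
Compound 2 `COc1ccc(CN(C(=O)CSC(=S)N2CCN(C(=O)OC(C)(C)C)CC2)c2cc(OC)c(OC)c(OC)c2)cc1`: 620 nM
Compound 3 `COc1ccc(CN(C(=O)CSC(=S)N2CCN(C(=O)OC(C)(C)C)CC2)c2ccc(Br)cc2)cc1`: > 20000 nM

Of the compounds shown here, three sharing one core have been tested in a functional assay on HCT-116 cells (Homo sapiens) for inhibition, read by CCK-8 assay, with a stated time of 48 h; a lower number here means a stronger inhibitor, a higher number a weaker inhibitor. Compound 1 gives 1370 nM. Compound 2 gives 620 nM, the lowest of the two plain numbers shown; the change a 2.2-fold lower number from compound 1 to compound 2 (0.34 log units; beyond the scatter) separates them. Compound 3 reaches only a limit of this assay, > 20000 nM, and is therefore not a number. The step of an at least 32-fold higher number from compound 2 to compound 3 (1.50 log units; beyond the scatter) rests on that limit, as stated by the limit of > 20000 nM in this assay, at which 1 of the 3 values shown sits.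

Compound 4 `COc1ccc(CN(C(=O)CSC(=S)N2CCN(C(=O)OC(C)(C)C)CC2)c2cc(OC)c(OC)c(OC)c2)cc1N=[N+]=[N-]` differs from compound 2 by azido in place of hydrogen on an aromatic carbon, so that the 4-methoxybenzyl of compound 2 becomes 3-azido-4-methoxybenzyl. Neither measured step touches this ring: one changes the group on a carbonyl carbon, the other the group on the amide-type nitrogen. Within the data shown here, no measured step therefore bears on this change, and the expectation is a step no larger than the scatter, a 1.0-fold lower number from compound 2 to compound 4 (0.01 log units; within the scatter). Compound 4 is estimated at 600 nM, expected to lie between 250 nM and 1500 nM.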

Compound 4, half-maximal inhibitory concentration: 780 nM
For compound 4 the middle estimate is 1.3-fold (0.11 log units) below the measured one; measured number inside the range.
By their numbers in this assay, from the lowest: compounds 2, 4 and 1 (each within the scatter of the next, the first and the last beyond it). At a limit, above all of these: compound 3.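

Compound 1, compound 2 and compound 3 differ only at the carbonyl group and on the amide-type nitrogen, so the ring carrying the 4-methoxybenzyl group had not been probed until this change. In this assay, placing azido ortho to the methoxy group gives a 1.3-fold higher number from compound 2 to compound 4 (0.10 log units; within the scatter), so compound 2 and compound 4 cannot be told apart, and this position carries the three extra nitrogen atoms with no measurable effect on the number. Nothing shown explains why this step stays within the scatter.

As far as these compounds go, it remains open whether the same position would accept an amine, a carboxylic acid or a longer chain equally well. From the compounds shown here alone, it is also open whether azido at this position would behave the same way on a core with a different amide-type nitrogen substituent, such as the 4-bromophenyl of compound 3.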